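Enlarging the Ring of Compound 2

The source may hold more compounds than are shown below. What is called first, only, known or untested is meant among the compounds shown, and "the series" means these compounds.

In an ADME assay on S9 fraction from liver (Rattus norvegicus) for metabolic stability, with a stated time of 1 h (on this read-out lower numbers stand for a less stable compound and higher numbers for a more stable compound), compound 2 `N#Cc1cnc(NCc2cnccc2C(F)(F)F)cc1NC[C@H]1C[C@H](O)C1` gives 61%. This lies within the scatter of compound 1 `N#Cc1cnc(NCc2cnccc2C(F)(F)F)cc1N[C@H]1C[C@@H](O)C1` at 70% and clearly higher than compound 3 `N#Cc1cnc(NCc2ccccc2C(F)(F)F)cc1N[C@H]1CC[C@@H](O)CC1` at 31%. Compound 4 `N#Cc1cnc(NCc2cnccc2C(F)(F)F)cc1NC[C@H]1CC[C@@H](O)CC1` differs from compound 2 in one group: 4-hydroxycyclohexyl in place of 3-hydroxycyclobutyl on a saturated chain carbon bound to a nitrogen on an aromatic ring. Within the data shown here, the only measured step nearby is a number 9 percentage points lower from compound 1 to compound 2 (within the scatter), which lies within the scatter but leaves the ring size unchanged. Compound 3 also carries 4-hydroxycyclohexyl, though it differs elsewhere too, so its 31% offers only a weak hint of a fall in this assay. The estimated change is a number 16 percentage points lower from compound 2 to compound 4 (beyond the scatter), beyond the scatter but uncertain. For compound 4, the expected value is 45%, with an estimated range of 25% to 65%.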

Compound 4, percent of the compound remaining: 18%
Estimate against measurement, compound 4: 27 percentage points above; the whole stated range lies above it.
By their numbers in this assay, from the lowest: compound 4; then compound 3; then compounds 2 and 1 (each within the scatter of the next).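

In this assay, among these compounds, the size of the ring at this position matters far more than the earlier compounds could show. On a saturated chain carbon bound to a nitrogen on an aromatic ring, 4-hydroxycyclohexyl in place of 3-hydroxycyclobutyl gives a number 43 percentage points lower from compound 2 to compound 4 (beyond the scatter). The full change on that nitrogen, (4-hydroxycyclohexyl)methyl in place of 3-hydroxycyclobutyl, gives a number 52 percentage points lower from compound 1 to compound 4 (beyond the scatter), far more than the step with the cyclobutyl ring kept, a number 9 percentage points lower from compound 1 to compound 2 (within the scatter).

As far as these compounds go, how a 3-hydroxycyclopentyl group, or an amine in place of the hydroxyl, would behave on this chain stays open. Nothing shown here explains why the two rings differ so sharply.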